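The source may report more compounds than this note shows. Statements on the series, on what has been measured and on what is new or still open speak of the compounds shown alone.

In a functional assay on PC-3 cells (Homo sapiens) for antiproliferative activity, read by MTT assay, with a stated time of 24 h (a lower number here means a stronger inhibitor, a higher number a weaker inhibitor), three compounds that share one core and differ in the group on an amide-type nitrogen have been measured. Compound 1 `CCn1c(C(=O)NCC(=O)OC)ccc1C(CC)(CC)c1ccc(OCS(=O)(=O)c2ccccc2)c(C)c1` gives > 50000 nM, which is a limit and not a number. Compound 2 `CCn1c(C(=O)NCCC(=O)OC)ccc1C(CC)(CC)c1ccc(OCS(=O)(=O)c2ccccc2)c(C)c1` gives 40400 nM, and compound 3 `CCn1c(C(=O)N[C@H](CO)C(C)C)ccc1C(CC)(CC)c1ccc(OCS(=O)(=O)c2ccccc2)c(C)c1` gives 7300 nM. Compound 3 therefore holds the lower of the two true numbers, and it also sits clearly under the limit reached by compound 1.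

Compound 4 `CCn1c(C(=O)N[C@@H](CO)CCO)ccc1C(CC)(CC)c1ccc(OCS(=O)(=O)c2ccccc2)c(C)c1` keeps the core but changes the group once more: 3-hydroxy-1-(hydroxymethyl)propyl in place of 1-(hydroxymethyl)-2-methylpropyl on an amide-type nitrogen. On the amide-type nitrogen, 3-hydroxy-1-(hydroxymethyl)propyl stands in place of 1-(hydroxymethyl)-2-methylpropyl. Within the data shown here, no measured step makes this exact swap, but two steps at the same nitrogen bear on it. One is a 5.5-fold lower number from compound 2 to compound 3 (0.74 log units; beyond the scatter), and the other is an at least 6.8-fold lower number from compound 1 to compound 3 (0.83 log units; beyond the scatter). Both show that this group can move the result, and both end at compound 3, so its number is the lowest yet seen, not a typical one. A modest step towards a higher number is therefore expected in this assay, although a step within the scatter would be no surprise. The expected change is a 2.5-fold higher number from compound 3 to compound 4 (0.39 log units; beyond the scatter). Compound 4 is estimated at 18000 nM, with an expected range of 6000 nM to 50000 nM.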

Compound 4, half-maximal inhibitory concentration: 14100 nM
Compound 4: the middle estimate sits 1.3-fold (0.11 log units) above what was measured; measured number inside the range.
By their numbers in this assay, from the lowest: compounds 3 and 4 (each within the scatter of the next); then compound 2. At a limit, above all of these: compound 1.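

In this assay, placing 3-hydroxy-1-(hydroxymethyl)propyl on the amide-type nitrogen in place of 1-(hydroxymethyl)-2-methylpropyl gives a 1.9-fold higher number from compound 3 to compound 4 (0.29 log units; within the scatter), so this change in make-up, from 5 carbon and 1 oxygen to 4 carbon and 2 oxygen, does not clearly separate the two groups in this assay. Compound 4 still stands apart from the two compounds carrying methoxycarbonyl groups, with a 2.9-fold lower number from compound 2 to compound 4 (0.46 log units; beyond the scatter) and an at least 3.5-fold lower number from compound 1 to compound 4 (0.54 log units; beyond the scatter), so across these four compounds, the two groups carrying a hydroxymethyl give lower numbers than the two methyl esters, and no compound shown goes against this. The step from compound 1 gives only a floor, since compound 1 stands at a limit: the limit of > 50000 nM in this assay, at which 1 of the 4 values shown sits.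

As far as these compounds go, whether an amine or a carboxylic acid on this nitrogen would give a number like those of compound 3 and compound 4, or one nearer those of the esters, remains open. Also open, from the compounds shown here alone, are what a plain alkyl chain with no hydroxy group would give and whether a longer chain ending in hydroxy would keep the number in this range.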